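Swapping bromo for amino in a cytotoxicity series

The compounds below may be only part of what the source reports. "The series", "measured", "known", "first", "only" and "open" are said of these compounds alone.

Compound 1 `Fc1cccc(-c2nc(Nc3ccccc3)c3cc(F)ccc3n2)c1`: 45500 nM
Compound 2 `COc1ccccc1Nc1nc(-c2cccc(F)c2)nc2ccc(F)cc12`: > 50000 nM, a limit
Compound 3 `Fc1cccc(-c2nc(Nc3ccc(Br)cc3)c3cc(F)ccc3n2)c1`: > 50000 nM, a limit

All three compounds were tested in a functional assay on U-937 cells (Homo sapiens) for cytotoxicity, read by MTT assay, with a stated time of 48 h; on this read-out higher numbers stand for weaker inhibition and lower numbers for stronger inhibition. Compound 3 has no number on this read-out, since its > 50000 nM is a limit. The same holds for compound 2, which leaves the picture thin: the limit of > 50000 nM in this assay, at which 2 of the 3 values shown sit.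

Compound 4 `Nc1ccc(Nc2nc(-c3cccc(F)c3)nc3ccc(F)cc23)cc1` differs from compound 3 in one place, with amino in place of bromo on an aromatic carbon. For the measured compounds named here, two measured steps bear on this change. One is an at least 1.0-fold higher number from compound 1 to compound 3 (0.04 log units; that floor lies within the scatter), the other at least 1.0-fold higher number from compound 1 to compound 2 (0.04 log units; that floor lies within the scatter). Both are only floors, and a step that the two limits leave unreadable from compound 2 to compound 3 adds nothing further. Going by the values given here, no measured compound carries amino. Among the compounds with values here, the expectation therefore rests on those two steps and on compound 1, whose 45500 nM is the only number in the set. Within the data shown here, no step clearly beyond the scatter is expected, with any movement more likely towards a lower number. The expected step is an at least 1.1-fold lower number from compound 3 to compound 4 (0.07 log units; that floor lies within the scatter). For compound 4 the estimate is 42000 nM, with an expected range of 12000 nM to 50000 nM.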

Compound 4, half-maximal inhibitory concentration: > 50000 nM
Compound 4 gave a limit, no number; the forecaster's own chance of this, stated with the estimate: 50%; at least 1.1-fold (0.07 log units) between middle value and limit.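

Amino on this carbon, para to a large group, gives a limit and no number in this assay, just as bromo does, so a second, different group at this position fails to bring a readable value, and the set narrows further: the limit of > 50000 nM in this assay, at which 3 of the 4 values shown sit. Against the hydrogen of compound 1, the change gives an at least 1.0-fold higher number from compound 1 to compound 4 (0.04 log units; that floor lies within the scatter), so it shows no clear shift in either direction. The steps to compound 4 from compound 3 and from compound 2 cannot be read, with limits at both ends.

Going by these compounds, whether any group on this carbon can give a number clearly lower than that of compound 1, 45500 nM, remains open. A hydroxy group or a carboxylic acid in the same place could test that in this assay.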